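The compounds below may be only part of what the source reports. "The series", "measured", "known", "first", "only" and "open" are said of these compounds alone.

Compound 3 `CCCCN(O)C(=O)Nc1cc([C@@H]2CC[C@@H](c3cc(OC)c(OC)c(OC)c3)O2)cc(OC)c1OCCS(=O)(=O)c1ccccc1Br` stands lowest of the three measured compounds in a functional assay on the whole organism for inhibition, with Mus musculus as the target, at a dose of 3 mg/kg (on this read-out higher numbers stand for more inhibition at the one dose given (going by the name of the read-out) and lower numbers for less inhibition), where compound 3 gives 9%. Compound 1 `CCCCN(O)C(=O)Nc1cc([C@@H]2CC[C@@H](c3cc(OC)c(OC)c(OC)c3)O2)cc(OC)c1OCCSc1ccc(Cl)cc1` gives 39%, and compound 2 `CCCCN(O)C(=O)Nc1cc([C@@H]2CC[C@@H](c3cc(OC)c(OC)c(OC)c3)O2)cc(OC)c1OCCSc1cccc(Br)c1` gives 40%. Compound 4 `CCCCN(O)C(=O)Nc1cc([C@@H]2CC[C@@H](c3cc(OC)c(OC)c(OC)c3)O2)cc(OC)c1OCCSc1ccc(OC)cc1` carries the change ((4-methoxyphenyl)sulfanyl in place of (2-bromophenyl)sulfonyl on a saturated chain carbon, two bonds along the chain from an oxygen on an aromatic ring). Within the data shown here, two measured steps bear on this change, since each of them swapped a sulfanyl link for a sulfonyl one: a number 30 percentage points lower from compound 1 to compound 3 (beyond the scatter) and a number 31 percentage points lower from compound 2 to compound 3 (beyond the scatter). Undoing that swap in compound 4 is therefore expected to restore most of the lost inhibition, a step estimated as a number 29 percentage points higher from compound 3 to compound 4 (beyond the scatter). Compound 4 is expected to give about 38%, with a range from 20% to 55%.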

Compound 4, a percentage reported as inhibition, in the whole organism at one dose (the size of the read-out at that dose, not a potency): 3%
The estimate for compound 4 lay 35 percentage points above the measured number; measured number outside the range, below it.
By their numbers in this assay, from the lowest: compounds 4 and 3 (each within the scatter of the next); then compounds 1 and 2 (each within the scatter of the next).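

In this assay, a sulfanyl link on this chain carbon does not by itself keep inhibition: putting (4-methoxyphenyl)sulfanyl in place of (2-bromophenyl)sulfonyl gives a number 6 percentage points lower from compound 3 to compound 4 (within the scatter). The group on the aromatic ring also counts, since methoxy in place of chloro gives a number 36 percentage points lower from compound 1 to compound 4 (beyond the scatter), and 4-methoxyphenyl in place of 3-bromophenyl gives a number 37 percentage points lower from compound 2 to compound 4 (beyond the scatter). No measurement here explains this loss of inhibition. Still open, on these data alone, is whether the loss is specific to methoxy, or whether an amine or a methyl on that aromatic ring would give the same low number.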